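Swapping the Piperidine Ring for a Pyrrolidine Ring

The compounds below may be only part of what the source reports. "The series", "measured", "known", "first", "only" and "open" are said of these compounds alone.

Compound 1 `O=c1cc(-c2ccccc2)oc2cc(OCc3ccccc3)c(OCCCCN3CCCCC3)c(O)c12`: 2400 nM
Compound 2 `O=c1cc(-c2ccccc2)oc2cc(OCc3ccccc3)c(OCCCN3CCCCC3)c(O)c12`: 2200 nM
Compound 3 `COc1cc2oc(-c3ccccc3)cc(=O)c2c(O)c1OCCCCN1CCCCC1`: 21000 nM

In a functional assay on HepG2 cells (Homo sapiens) for antiproliferative activity, read by MTT assay, with a stated time of 48 h (a lower number here means a stronger inhibitor, a higher number a weaker inhibitor), compound 3 gives 21000 nM, the highest number of the three, which makes it the weakest inhibitor of this set. Compound 4 `COc1cc2oc(-c3ccccc3)cc(=O)c2c(O)c1OCCCCN1CCCC1` has the same structure except for one change: pyrrolidin-1-yl in place of piperidin-1-yl on a saturated chain carbon, four bonds along the chain from an oxygen on an aromatic ring. In words, pyrrolidin-1-yl stands in place of piperidin-1-yl on a saturated chain carbon, four bonds along the chain from an oxygen on an aromatic ring.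

Among the measured compounds shown here, no measured step swaps one of these rings for the other, so the evidence is indirect. The closest step puts piperidin-1-yl in place of (piperidin-1-yl)methyl, and it is small: a 1.1-fold lower number from compound 1 to compound 2 (0.04 log units; within the scatter). A larger step, hydrogen in place of phenyl, concerns a different group: an 8.8-fold higher number from compound 1 to compound 3 (0.94 log units; beyond the scatter). No step beyond the scatter is therefore expected in this assay. The expected result is a 1.1-fold lower number from compound 3 to compound 4 (0.04 log units; within the scatter). The estimate for compound 4 is 19000 nM, with an expected range of 9000 nM to 40000 nM.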

Compound 4, half-maximal inhibitory concentration: 4900 nM
Beside the measured number, compound 4's estimate is 3.9-fold (0.59 log units) above it; measured number outside the range, below it.
By their numbers in this assay, from the lowest: compounds 2 and 1 (each within the scatter of the next); then compound 4; then compound 3.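

In this assay the ring at the end of the chain does matter: moving from the six-membered piperidin-1-yl to the five-membered pyrrolidin-1-yl gives a 4.3-fold lower number from compound 3 to compound 4 (0.63 log units; beyond the scatter). Among the compounds shown here, the only earlier change in this side chain, on a different background, was a 1.1-fold lower number from compound 1 to compound 2 (0.04 log units; within the scatter), so that end of the molecule had seemed to tolerate change; the new step shows that the identity of the ring counts even though the two groups match in charge and in hydrogen-bond donors and acceptors. Nothing available explains why the five-membered ring gives the lower number.

On these data alone, it remains open whether the same swap would act alike on compound 1, which carries phenyl where compound 3 has hydrogen. Also open, as far as these compounds go, is how a morpholine ring or an open dimethylamino group would compare at this chain end.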